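Returning to a chain-borne amine on the shared core

The compounds below may be only part of what the source reports. "The series", "measured", "known", "first", "only" and "open" are said of these compounds alone.

Compound 3 `CCCCCCCCCCc1ccc(-c2noc(-c3cccc(CN)c3)n2)cc1` stands lowest of the three compounds measured in an assay on HeLa cells for inhibition of sphingosine-1-phosphate transporter SPNS2 (Mus musculus), read by LC-MS, tested at 2 uM; a higher number here means more inhibition at the concentration tested (going by the name of the read-out), a lower number less inhibition: compound 3 gives 2%, whereas compound 1 `CCCCCCCCCCc1ccc(-c2noc(CCCN)n2)cc1` gives 67% and compound 2 `CCCCCCCCCCc1ccc(-c2noc(C3CCNCC3)n2)cc1` gives 66%. Compound 4 `CCCCCCCCCCc1ccc(-c2noc([C@H](N)CCCCN)n2)cc1` differs from compound 3 in one place: 1,5-diaminopentyl in place of 3-(aminomethyl)phenyl on an aromatic carbon. For the measured compounds named here, the steps that bear on this change run the other way, into the aryl group: a number 65 percentage points lower from compound 1 to compound 3 (beyond the scatter) and a number 64 percentage points lower from compound 2 to compound 3 (beyond the scatter). Both replaced a group with no ring by the 3-(aminomethyl)phenyl group and both were large. Compound 4 again carries a group with no ring and two hydrogen-bond donors, so a large rise is expected in this assay, estimated as a number 56 percentage points higher from compound 3 to compound 4 (beyond the scatter). Compound 4 is therefore expected to give about 58%, within 35% to 80%.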

Compound 4, a percentage reported as inhibition, at one concentration (the size of the read-out at that concentration, not a potency): 50%
For compound 4 the middle estimate is 8 percentage points above the measured one, within the range that was stated.
By their numbers in this assay, from the lowest: compound 3; then compound 4; then compounds 2 and 1 (each within the scatter of the next).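

The 1,5-diaminopentyl group gives a number 48 percentage points higher from compound 3 to compound 4 (beyond the scatter) in this assay and so undoes most of the loss seen with 3-(aminomethyl)phenyl at this position. It still falls short of the earlier groups, with a number 16 percentage points lower from compound 2 to compound 4 (beyond the scatter) and a number 17 percentage points lower from compound 1 to compound 4 (beyond the scatter) on the same carbon, so a group with no ring does not by itself reach the higher level, which compound 2 holds with piperidin-4-yl. No measurement here accounts for these gaps. Open remains how the mirror-image form of the stereocentre, a guanidine in place of the chain-end amine, or a longer chain would fare here.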